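Fluoro in place of methoxy on compound 2

A few compounds are considered here, and "the series" means these few. Any claim that something is new, unique, unknown or untested is made for them only; others in the source may bear on it.

compound 1 `Cc1cc(NC(=O)Nc2ccc(Cl)c(Cl)c2)c2ccccc2n1` gives 17000 nM
compound 2 `COc1ccc(NC(=O)Nc2cc(C)nc3ccccc23)cc1OC` gives > 25000 nM (a limit)
compound 3 `Cc1cc(NC(=O)Nc2ccc3[nH]cnc3c2)c2ccccc2n1` gives > 25000 nM (a limit)

These three readings come from an ADME assay on HepG2 cells (Homo sapiens) for cytotoxicity, with a stated time of 72 h (on this read-out higher numbers stand for an effect only at larger amounts of compound and lower numbers for an effect already at smaller amounts), and only compound 1 gives an actual number. Compound 2 stands at the limit of > 25000 nM in this assay, at which 2 of the 3 values shown sit (a limit, not a number).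

The next compound to be measured is compound 4 `COc1ccc(NC(=O)Nc2cc(C)nc3ccccc23)cc1F`, which keeps the shared core of compound 2 and changes one group (fluoro in place of methoxy on an aromatic carbon). In words, it carries fluoro in place of methoxy on an aromatic carbon, ortho to a methoxy group and meta to a large group.

Among the compounds with values here, no two measured compounds differ in just one place, so the effect of a swap like this has not been seen directly. Within the data shown here, the only guide is compound 1 (17000 nM), which shows that a real number can appear with this core. In this assay no step beyond the usual scatter is expected, and any small move should be towards lower numbers. The expected step is a number no higher from compound 2 to compound 4 (the limit leaves the size open) on this reasoning.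

Compound 4 is estimated at 25000 nM (expected range 13000 nM to 40000 nM).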

Compound 4, half-maximal effective concentration: > 25000 nM
Compound 4 was reported as a limit; the forecaster's own chance of this, stated with the estimate: 65%; the middle value lies on the limit itself.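

Within the data shown here, compound 2 and compound 4 both give only a limit rather than an actual number, so no step between them can be read: the limit of > 25000 nM in this assay, at which 3 of the 4 values shown sit.

The compounds shown leave open whether fluoro in place of methoxy on this shared core shifts the value at all, since neither compound has an actual number for comparison.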